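This account rests on a few compounds, and the source may have more. Where it says the series, first, only, none or still open, it means among the compounds named here.

Compound 1 `C#CCO/N=C/c1c(-c2ccc(F)cc2)nc2c(C)cccn12` needs the larger dose of the two compounds measured in a functional assay on the whole organism (strain NMRI) with Mus musculus as the target, with a stated time of 4 h; a lower number here means that less compound is needed, a higher number that more compound is needed for the effect: compound 1 gives 100 mg/kg, while compound 2 `Cc1cccn2c(/C=N/OCc3cn(Cc4ccc([N+](=O)[O-])cc4)nn3)c(-c3ccc(F)cc3)nc12` gives 40 mg/kg, a gap beyond the usual scatter. Compound 3 `C#CCO/N=C/c1c(-c2ccccc2)nc2c(C)cccn12` differs from compound 1 in one place: hydrogen in place of fluoro on an aromatic carbon. Among the measured compounds shown here, no measured pair shows what this change does here, so only a small step, not beyond the scatter and in no particular direction, is expected from compound 1 to compound 3 in this assay, namely no change at the digits printed from compound 1 to compound 3 (within the scatter). Compound 3 is therefore estimated at 100 mg/kg, within a range from 50 mg/kg to 200 mg/kg.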

Compound 3, minimum effective dose: 100 mg/kg
Compound 3: the middle estimate sits on the measured number at the digits printed; measured number inside the range.
By their numbers in this assay, from the lowest: compound 2; then compounds 1 and 3 (each within the scatter of the next).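

Replacing the fluoro of the 4-fluorophenyl group with hydrogen gives no change at the digits printed from compound 1 to compound 3 (within the scatter) in this assay, so for this pair the fluoro at this place on the ring is not needed to hold the dose. Among the compounds shown here, the earlier compounds offered no pair differing in one place, so this is the first direct reading of any single change. No supporting data are available to explain this result.
As far as these compounds go, whether an amine or a carboxylic acid at this place would shift the dose remains open. So does whether the same swap would read alike on compound 2.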